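The compounds below may be only part of what the source reports. "The series", "measured", "known", "first", "only" and "open" are said of these compounds alone.

Measured so far in an ADME assay on NIH3T3 cells (Mus musculus) for cytotoxicity, read by MTT assay, with a stated time of 24 h; on this read-out higher numbers stand for weaker inhibition and lower numbers for stronger inhibition:
- compound 1 `O=C(CSc1nnc(-c2ccncc2)o1)N/N=C/c1ccc(F)cc1`; compound 1 gives 170000 nM
- compound 2 `O=C(CSc1nnc(-c2ccncc2)o1)N/N=C/c1ccccc1F`; compound 2 gives 142000 nM
- compound 3 `O=C(CSc1nnc(-c2ccncc2)o1)N/N=C/c1cc(Br)ccc1O`; compound 3 gives 156000 nM

Compound 3 stands second highest of the three numbers in this assay. Its nearest neighbour is compound 1, a 1.1-fold lower number from compound 1 to compound 3 (0.04 log units; within the scatter); its furthest is compound 2, a 1.1-fold higher number from compound 2 to compound 3 (0.04 log units; within the scatter). All three numbers sit close together, and no order can be read among them.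

Compound 4 `O=C(CSc1nnc(-c2ccncc2)o1)N/N=C/c1cc(Cl)cc(Cl)c1O` is the next step from compound 3: 3,5-dichloro-2-hydroxyphenyl in place of 5-bromo-2-hydroxyphenyl on a carbon with a double bond to nitrogen. Every measured step in the series already concerns the aryl group on the carbon with a double bond to nitrogen, so all three bear on this change: a 1.2-fold lower number from compound 1 to compound 2 (0.08 log units; within the scatter), a 1.1-fold lower number from compound 1 to compound 3 (0.04 log units; within the scatter) and a 1.1-fold higher number from compound 2 to compound 3 (0.04 log units; within the scatter). Each of these exchanges, whether of a fluorine position or of a fluorophenyl for a bromo-hydroxyphenyl, left this assay essentially unmoved. Exchanging the halogen pattern on a hydroxyphenyl that is otherwise retained is a change of the same kind, and nothing in the series points to a direction.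

Accordingly no step beyond the scatter is expected, a 1.0-fold lower number from compound 3 to compound 4 (0.00 log units; within the scatter), and compound 4 is estimated at 155000 nM in this assay, with a range from 80000 nM to 300000 nM.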

Compound 4, half-maximal inhibitory concentration: 171000 nM
Estimate against measurement, compound 4: 1.1-fold (0.04 log units) below, within the range that was stated.
By their numbers in this assay, from the lowest: compounds 2, 3, 1 and 4 (each within the scatter of the next).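

The 3,5-dichloro-2-hydroxyphenyl group on the carbon with a double bond to nitrogen shows that a dichloro pattern on the hydroxyphenyl is also accommodated in this assay without a step beyond the scatter, with a 1.1-fold higher number from compound 3 to compound 4 (0.04 log units; within the scatter) when it replaces 5-bromo-2-hydroxyphenyl. Set against the two fluorophenyl compounds, the result is the same, with a 1.2-fold higher number from compound 2 to compound 4 (0.08 log units; within the scatter) and a 1.0-fold higher number from compound 1 to compound 4 (0.00 log units; within the scatter) as the readings, so the four aryl groups shown form one group of values with no order among them in this assay. No measurement is at hand that would explain this insensitivity of the number to the aryl group.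

As far as these compounds go, all four compounds carry a halogenated phenyl on this carbon and share the core of compound 1, so an amine, a carboxylic acid or a longer chain in place of the aryl group remains open, as do changes elsewhere on the core. Whether any group at this place can move the number in this assay beyond the scatter, in either direction, also stays unanswered.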